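Pyridine substituent change: methoxy, difluoromethyl, 1-methoxyethyl

The source may hold more compounds than are shown below. What is called first, only, known or untested is meant among the compounds shown, and "the series" means these compounds.

Measured in an assay on T-REx-293 cells for inhibition of potassium channel subfamily T member 1 (Homo sapiens), read by patch clamp; on this read-out lower numbers stand for stronger inhibition and higher numbers for weaker inhibition:
Compound 1, `COc1cc(-c2noc([C@H](C)NC(=O)c3cc(C(F)(F)F)nn3C)n2)ccn1`: 27 nM
Compound 2, `C[C@H](NC(=O)c1cc(C(F)(F)F)nn1C)c1nc(-c2ccnc(C(F)F)c2)no1`: 61 nM

Among the compounds with values here, compound 2 carries the higher of the two numbers; the one step from methoxy to difluoromethyl on the aromatic carbon, a 2.3-fold higher number from compound 1 to compound 2 (0.35 log units; beyond the scatter), is beyond the scatter but modest.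

Compound 3, `CO[C@H](C)c1cc(-c2noc([C@H](C)NC(=O)c3cc(C(F)(F)F)nn3C)n2)ccn1`, is not yet measured. The change from compound 2 is 1-methoxyethyl in place of difluoromethyl on an aromatic carbon. Within the data shown here, no measured step covers this exact exchange; the only related information is the step from compound 1 to compound 2, which shows that going from an oxygen-bearing group to difluoromethyl at this place raised the number modestly. As far as these compounds go, compound 3 returns an oxygen acceptor at the same place, so a modest move back toward the number of compound 1 is expected, though the extra carbon chain is untested. The estimate for compound 3 in this assay is 35 nM, range 14 nM to 90 nM, a step of a 1.7-fold lower number from compound 2 to compound 3 (0.24 log units; within the scatter).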

Compound 3, half-maximal inhibitory concentration: 778 nM
The estimate for compound 3 lay 22-fold (1.35 log units) below the measured number; measured number outside the range, above it.
By their numbers in this assay, from the lowest: compound 1; then compound 2; then compound 3.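

In this assay, the place next to the ring nitrogen proves far less forgiving than the first exchange suggested: the earlier change gave only a modest shift (a 2.3-fold higher number from compound 1 to compound 2 (0.35 log units; beyond the scatter)), whereas 1-methoxyethyl gives a large one against difluoromethyl (a 13-fold higher number from compound 2 to compound 3 (1.11 log units; beyond the scatter)) and against methoxy (a 29-fold higher number from compound 1 to compound 3 (1.46 log units; beyond the scatter)). Methoxy and 1-methoxyethyl both carry an oxygen, so the presence of oxygen at this place does not by itself keep the number low. Nothing available accounts for the size of this loss.

The compounds shown leave open whether the loss tracks the added carbons, the branching or the defined stereocentre. Ethoxy, methoxymethyl or the opposite stereocentre of 1-methoxyethyl at this place would help separate these readings.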